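Swapping the Ring Substituent of Compound 2

The source may hold more compounds than are shown below. What is called first, only, known or untested is meant among the compounds shown, and "the series" means these compounds.

Measured compounds:
- compound 1, `CC(C)CNC(=O)n1c(=O)oc2ccc(C3CCN(C)CC3)cc21`, 295 nM
- compound 2, `CC(=O)N1CCC(c2ccc3c(c2)oc(=O)n3C(=O)NCCCCc2ccccc2)CC1`, 64 nM
- compound 3, `CC(C)CNC(=O)n1c(=O)oc2c(C3CCN(C)CC3)cccc21`, 535 nM

All three compounds share a core and were tested in an assay on HEK293 cells for inhibition of acid ceramidase (Homo sapiens), read by fluorescence, with stated times of 10 min and 3 h; a higher number here means a weaker inhibitor, a lower number a stronger inhibitor. Among them compound 2 gives the lowest number, with 64 nM; compound 1 stands higher at 295 nM, and compound 3 higher still at 535 nM. Both gaps to compound 2 lie beyond the usual scatter, so compound 2 is the strongest inhibitor of the three on these numbers.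

The unmeasured compound 4, `CC(C)CN1CCN(c2ccc3c(c2)oc(=O)n3C(=O)NCCCCc2ccccc2)CC1`, keeps everything of compound 2 except one group on the aromatic ring: 4-isobutylpiperazin-1-yl in place of 1-acetylpiperidin-4-yl on an aromatic carbon. Among the compounds with values here, no pair of measured compounds differs in just one place, so there is no measured step to lean on for this kind of exchange.

With nothing to anchor the direction, the expectation for compound 4 is a step from compound 2 that stays close to the scatter, a 1.6-fold higher number from compound 2 to compound 4 (0.19 log units; within the scatter), with a modest lean toward a weaker inhibitor. Compound 4 is estimated at 100 nM in this assay, within a range from 30 nM to 400 nM.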

Compound 4, half-maximal inhibitory concentration: 127 nM
Estimate against measurement, compound 4: 1.3-fold (0.10 log units) below; the measured number falls inside the stated range.
By their numbers in this assay, from the lowest: compounds 2 and 4 (each within the scatter of the next); then compounds 1 and 3 (each within the scatter of the next).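

In this assay, within the data shown here, placing 4-isobutylpiperazin-1-yl on the aromatic carbon that carries 1-acetylpiperidin-4-yl gives a 2.0-fold higher number from compound 2 to compound 4 (0.30 log units; within the scatter), the first step here in which only one place changes. This exchange is not a small edit: the entering group has one more heavy atom and a second ring nitrogen, has no double bond outside the ring, and has its branched chain where the leaving group has its acetyl group, yet the two numbers cannot be told apart. At this position, with the rest of compound 2 held fixed, these two six-membered rings therefore serve equally well in this assay. No measurement here speaks to any one feature of either group.

On these data alone, it remains open whether a much smaller or otherwise different group on this carbon, such as a methoxy group, an unsubstituted piperazin-1-yl ring with its free amine, or a carboxylic acid, would also stay this close to compound 2. Among these compounds, the same exchange also remains to be read on a compound with a different side chain, such as the one carried by compound 1.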